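The source may hold more compounds than are shown below. What is called first, only, known or untested is meant among the compounds shown, and "the series" means these compounds.

Four compounds share a carboxylic acid chain on a bicyclic ring system joined through a single carbon to a second, chlorinated ring system, but they differ in small pieces. Compound 1 `CCOc1cc2[nH]c(Cc3nn(CC(=O)O)c(=O)c4ccccc34)nc2cc1Cl` carries an ethoxy group. Compound 2 `O=C(O)Cc1nn(Cc2cn3cc(OCC4CC4)c(Cl)cc3n2)c2ccccc2c1=O` has a different core, and compound 3 `C[C@H](C(=O)O)c1nn(Cc2cn3cc(OCC4CC4)c(Cl)cc3n2)c2ccccc2c1=O` is compound 2 with a 1-carboxyethyl chain in place of the carboxymethyl chain. Compound 4 `COc1cc2[nH]c(Cc3nn(CC(=O)O)c(=O)c4ccccc34)nc2cc1Cl` has not been measured yet. The difference between the core of compound 1 and the core of compound 3 is not broken down here.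

In a functional assay on CHO cells for antagonist activity at sphingosine 1-phosphate receptor 2 (Homo sapiens), read by GTPgammaS binding (a lower number here means a stronger inhibitor, a higher number a weaker inhibitor), compound 1 gives 109 nM, compound 2 gives 30 nM and compound 3 gives 16 nM. Compound 1 has the highest number of the three, and its gaps to compound 2 and to compound 3 both lie beyond the scatter, so it is the weakest measured inhibitor.

Within the data shown here, the one change seen twice is the loss of a methyl group. Between compound 3 and compound 2 it is hydrogen in place of methyl on a saturated chain carbon bound to an aromatic carbon and a carbonyl carbon and the step it made was a 1.9-fold higher number from compound 3 to compound 2 (0.27 log units; within the scatter). From compound 1 to compound 4 it is hydrogen in place of methyl on a saturated chain carbon bound to an oxygen on an aromatic ring. The two are the same kind of change, not the same: in the first the carbon sits bound to an aromatic carbon and a carbonyl carbon, in the second it is bound to an oxygen on an aromatic ring.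

Compound 4 is therefore expected to move only a little, by a 1.4-fold higher number from compound 1 to compound 4 (0.14 log units; within the scatter), an expectation that rests on the small size of the measured step of a 1.9-fold higher number from compound 3 to compound 2 (0.27 log units; within the scatter). Compound 4 is estimated to give 150 nM in this assay, plausibly between 60 nM and 400 nM.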

Compound 4, half-maximal inhibitory concentration: 241 nM
Beside the measured number, compound 4's estimate is 1.6-fold (0.21 log units) below it; measured number inside the range.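

Shortening the ethoxy group of compound 1 to the methoxy group of compound 4 gives a 2.2-fold higher number from compound 1 to compound 4 (0.34 log units; beyond the scatter) in this assay, so this one lost methyl group leaves a modest but real weakening on this core. Set beside the earlier loss of a methyl group on the other core, the new step shows that two steps of this kind, on two different cores, came out at a similar size: the same change on two cores in this assay, a 1.9-fold higher number (0.27 log units; within the scatter) from compound 3 to compound 2 and a 2.2-fold higher number (0.34 log units; beyond the scatter) from compound 1 to compound 4, 1.2-fold (0.07 log units) apart, within the scatter of two such steps This does not show that the change carries over as a general rule, since it rests on a single pair per core and the two methyl groups do not sit in the same place, one on a saturated chain carbon bound to an aromatic carbon and a carbonyl carbon, the other on a saturated chain carbon bound to an oxygen on an aromatic ring.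

As far as these compounds go, it remains open whether the same methyl loss at either place would give a similar step on the other core, for instance with the 1-carboxyethyl chain on the core of compound 1. Also open, from the compounds shown here alone, is how a longer chain such as propoxy, or an amine in place of the ethoxy group, would read in this assay.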